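Pyrimidin-5-yl in place of pyridin-3-yl on the shared core

The source may hold more compounds than are shown below. What is called first, only, known or untested is meant among the compounds shown, and "the series" means these compounds.

Compounds measured in a functional assay on HL-60 cells (Homo sapiens) for cytotoxicity, read by CellTiter-Blue, with a stated time of 48 h; on this read-out higher numbers stand for weaker inhibition and lower numbers for stronger inhibition
- Compound 1 `CCOC(=O)CC1C(C(=O)OCC)=C(N)Oc2ccc(-c3ccco3)cc21` gives > 80000 nM, a limit
- Compound 2 `CCOC(=O)CC1C(C(=O)OCC)=C(N)Oc2ccc(-c3cccnc3)cc21` gives 21500 nM

The reading for compound 1 is a limit and not a number. Among the compounds with values here, compound 2 therefore carries the only true number in this assay, at 21500 nM. Compound 3 `CCOC(=O)CC1C(C(=O)OCC)=C(N)Oc2ccc(-c3cncnc3)cc21` differs from compound 2 by one change, pyrimidin-5-yl in place of pyridin-3-yl on an aromatic carbon. Within the data shown here, one measured step bears on this, an at least 3.7-fold lower number from compound 1 to compound 2 (0.57 log units; beyond the scatter), where pyridin-3-yl replaced furan-2-yl. Its size is bounded by the limit of > 80000 nM in this assay, at which 1 of the 2 values shown sits, and it tests a different exchange, so it gives only a loose guide. No step beyond the scatter is therefore expected in this assay, though a slightly higher number is possible. The expected step is a 1.3-fold higher number from compound 2 to compound 3 (0.11 log units; within the scatter). Compound 3 is estimated at 28000 nM, with an expected range from 11000 nM to 70000 nM.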

Compound 3, half-maximal inhibitory concentration: 37900 nM
Compound 3: the middle estimate sits 1.4-fold (0.13 log units) below what was measured; the measured number falls inside the stated range.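

In this assay, the step of a 1.8-fold higher number from compound 2 to compound 3 (0.25 log units; within the scatter) shows that this position accepts pyrimidin-5-yl, a six-membered aromatic ring with 2 hetero atoms, in place of pyridin-3-yl, with 1, without a step beyond the scatter. The step of an at least 2.1-fold lower number from compound 1 to compound 3 (0.32 log units; beyond the scatter) shows that compound 3, like compound 2, stands apart from furan-2-yl, so this separation is not confined to pyridin-3-yl. Going by these compounds, the true size of that step stays open, since the reading for compound 1 is a limit: the limit of > 80000 nM in this assay, at which 1 of the 3 values shown sits.

The compounds shown leave open how a six-membered aromatic ring of carbon only, such as phenyl, would read at this position. They also leave open whether a group other than an aromatic ring, such as an amine or a carboxylic acid, would fit there.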